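The source may report more compounds than this note shows. Statements on the series, on what has been measured and on what is new or still open speak of the compounds shown alone.

Measured so far:

compound 1 `O=C(C1CCCCC1)N1N=CCC1c1ccccc1` gives 5.9
compound 2 `CC(C)(C)C(=O)N1CCSC1c1ccccc1` gives 5.6
compound 3 `CC(C)(C)C(=O)N1N=CCC1c1ccc(C(C)(C)C)cc1` gives 8

All three numbers come from a physicochemical assay for lipophilicity, read by HPLC, measured as chromatographic lipophilicity, at pH 7.4; on this read-out higher numbers stand for higher lipophilicity and lower numbers for lower lipophilicity. On that read-out compound 1 sits close to compound 2, the gap between the two lying within the usual scatter of repeated measurements, so nothing can be said about which is the more lipophilic. Compound 3, by contrast, stands well above compound 1, by a margin that is clearly beyond that scatter.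

The compound still to be measured is compound 4 `CC(C)(CO)C(=O)N1N=CCC1c1ccccc1`. It differs from compound 1 in one place only:

1-(hydroxymethyl)-1-methylethyl in place of cyclohexyl on a carbonyl carbon

For the measured compounds named here, no pair of measured compounds shows a matching change, so the size of this step cannot be read off from the numbers in hand; it has to be estimated. Going from cyclohexyl to 1-(hydroxymethyl)-1-methylethyl on a carbonyl carbon is expected to move the read-out of this assay downward, by a step well beyond the scatter, and the counted hydrogen-bond donor and acceptor that enter are the main ground for that expectation.

Compound 4 is therefore expected to give about 3.5 in this assay, most likely between 2.7 and 4.3. The change that this estimate implies is a number 2.40 log units lower from compound 1 to compound 4 (beyond the scatter), expected to be a clear fall.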

Compound 4, distribution coefficient: 3.4
Compound 4: the middle estimate sits 0.10 log units above what was measured; low and high end bracket the measured number.
By their numbers in this assay, from the lowest: compound 4; then compounds 2 and 1 (each within the scatter of the next); then compound 3.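

For the compounds shown here, this is the only step in the set so far that changes a single place, and it shows that the group on the carbonyl carbon has a strong hold on the read-out of this assay: replacing cyclohexyl with 1-(hydroxymethyl)-1-methylethyl gives a number 2.50 log units lower from compound 1 to compound 4 (beyond the scatter) and counts as a large step. The swap removes a carbon ring of 6 heavy atoms and brings in an open group of 5 heavy atoms with 1 hydrogen-bond donor and 1 hydrogen-bond acceptor, so a change of only one heavy atom in size comes with a large shift in the number. No measurement here explains why this swap moves the read-out so far.

The compounds shown leave open how much of the step goes with losing the ring and how much with gaining the hydroxyl, since both happen together in this one change. Also open, from the compounds shown here alone, is how the read-out at this place would respond to a methyl ether in place of the hydroxyl, to an amine, to a carboxylic acid or to a longer chain ending in a hydroxyl.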